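A few compounds are considered here, and "the series" means these few. Any claim that something is new, unique, unknown or untested is made for them only; others in the source may bear on it.

Within the data shown here, in an ADME assay on Vero cells (Chlorocebus sabaeus) for cytotoxicity, read by MTT assay, with a stated time of 96 h (on this read-out higher numbers stand for lower toxicity in this test and lower numbers for higher toxicity in this test), compound 1 `COc1ccc(-c2nc3cc(/C(C)=N/NC(N)=O)ccc3[nH]2)c(OC)c1` gives 80000 nM, the only true number in this small set. Compound 2 `CC(=O)c1ccc2c(c1)nc(-c1ccc(Cl)cc1)n2C1CCCCC1` reads > 100000 nM, which is a limit of the assay and not a number. Compound 3 `C/C(=N\NC(N)=O)c1ccc2c(c1)nc(-c1ccc(Cl)cc1)n2C1CCCCC1` reads > 100000 nM, again a limit. That leaves compound 3 at the limit of > 100000 nM in this assay, at which 2 of the 3 values shown sit, so its real position on the scale is not known. Among the measured compounds shown here, the one measured step is a step that the two limits leave unreadable from compound 2 to compound 3. It gives no size to carry forward, and it concerns a different place in the molecule.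

The next structure is compound 4 `COc1ccc(-c2nc3cc(/C(C)=N/NC(N)=O)ccc3n2C2CCCCC2)c(OC)c1`, which puts 2,4-dimethoxyphenyl in place of 4-chlorophenyl on an aromatic carbon. For the measured compounds named here, no measured step covers this exchange. Going by the values given here, the only guide is compound 1, which carries the same 2,4-dimethoxyphenyl group and gives 80000 nM. In this assay a small move towards lower numbers is therefore expected, or no change that can be read at all. The expected step is an at least 1.1-fold lower number from compound 3 to compound 4 (0.07 log units; that floor lies within the scatter), and it is only an estimate, given that it starts from a limit. For compound 4 the estimated value is 85000 nM, with an expected range of 35000 nM to 150000 nM.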

Compound 4, half-maximal cytotoxic concentration: 20000 nM
Estimate against measurement, compound 4: 4.3-fold (0.63 log units) above; the whole stated range lies above it.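

In this assay, among these compounds, the group on the aromatic carbon next to the ring atom that bears a cyclohexyl group turns out to matter: 2,4-dimethoxyphenyl in place of 4-chlorophenyl gives an at least 5.0-fold lower number from compound 3 to compound 4 (0.69 log units; beyond the scatter), the first readable change at this position and a sign of higher toxicity in this test. That size is only a floor, and the true step may be larger, because compound 3 sits at a limit of the assay and not at a number: the limit of > 100000 nM in this assay, at which 2 of the 4 values shown sit.

The aromatic nitrogen matters as well when the 2,4-dimethoxyphenyl group stays in place, since cyclohexyl in place of hydrogen gives a 4.0-fold lower number from compound 1 to compound 4 (0.60 log units; beyond the scatter), so the two changes can each be read against compound 4, though each from a different partner.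

Going by these compounds, it remains open whether one methoxy group alone would give the same shift, or whether a different group at this position, such as a simple phenyl, a pyridine ring or a phenyl bearing an amine or a carboxylic acid, would move the number in either direction. On these data alone, a shorter chain such as methyl or ethyl on the aromatic nitrogen, in place of cyclohexyl, also stays unexplored in this set.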